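This account rests on a few compounds, and the source may have more. Where it says the series, first, only, none or still open, it means among the compounds named here.

Notes on the series

The shared core of compound 3, shown as `NC(=O)c1c(NC(=O)c2ccccc2Cl)sc2c1CCN(C(=S)Nc1ccccc1)C2`, carries a thiourea on its saturated ring nitrogen. In a functional assay on HL-60 cells (Homo sapiens) for antiproliferative activity, with a stated time of 24 h (on this read-out lower numbers stand for stronger inhibition and higher numbers for weaker inhibition), compound 3 gives 5940 nM, the lowest of the two numbers recorded. The neighbouring compound 2, `NC(=O)c1c(NC(=O)c2cccc([N+](=O)[O-])c2)sc2c1CCN(Cc1c(Cl)cccc1Cl)C2`, with a different substitution pattern on both its amide and its benzyl group, gives 18400 nM in this assay; the gap between these two values lies beyond the scatter of repeated measurements. Compound 1, `NC(=O)c1c(NC(=O)c2ccc(C(F)(F)F)cc2)sc2c1CCN(Cc1ccccc1F)C2`, reaches only a limit of this assay at > 50000 nM, and the limit of > 50000 nM in this assay, at which 1 of the 3 values shown sits, marks where that limit sits. No pair among these three differs in a single place, so no measured step is available.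

Compound 4, `NC(=O)c1c(NC(=O)c2ccccc2Cl)sc2c1CCN(C(=S)Nc1cccnc1)C2`, differs from compound 3 by pyridin-3-yl in place of phenyl on an amide-type nitrogen. The thiocarbonyl and its attached nitrogen stay in place, the change being confined to the aromatic ring on that nitrogen.

Expectation for compound 4 in this assay: with nothing measured on a move between such rings in this series, the step is expected to stay within the scatter, with no clear direction, and is estimated at a 1.0-fold higher number from compound 3 to compound 4 (0.00 log units; within the scatter). On that basis compound 4 is estimated at 6000 nM, expected to fall between 2500 nM and 15000 nM.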

Compound 4, half-maximal inhibitory concentration: 33900 nM
Estimate against measurement, compound 4: 5.7-fold (0.75 log units) below, outside the stated range (above it).
By their numbers in this assay, from the lowest: compound 3; then compounds 2 and 4 (each within the scatter of the next). At a limit, above all of these: compound 1.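

Among the compounds shown here, this is the first measured single-place step, and it shows that the aromatic ring on the amide-type nitrogen of the thiourea is not a silent position: in this assay, pyridin-3-yl in place of phenyl gives a 5.7-fold higher number from compound 3 to compound 4 (0.76 log units; beyond the scatter). The change keeps the thiocarbonyl and the count of heavy atoms, swapping one ring carbon for a nitrogen and adding one hydrogen-bond acceptor by count, and that single exchange is enough to move the number to the weaker side, beyond the scatter. Nothing at hand bears on why this step occurs.

Going by these compounds, with a single replacement read at this position, it remains open whether the weaker number belongs to pyridin-3-yl alone or to ring nitrogens more generally, and how a pyridin-4-yl ring, a cyclohexyl ring or a phenyl ring bearing a methoxy group would read on the same nitrogen. On these data alone, the contribution of the thiourea itself also stays open, since compound 1 and compound 2 differ from compound 3 in more than one place.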